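Oxolan-3-yl in place of tert-butyl on a carbonyl carbon

A few compounds are considered here, and "the series" means these few. Any claim that something is new, unique, unknown or untested is made for them only; others in the source may bear on it.

Of the compounds shown here, three have been measured in an ADME assay on H9c2 cells (Rattus norvegicus) for cytotoxicity; a lower number here means a stronger inhibitor, a higher number a weaker inhibitor: compound 1 (`O=C(Nc1nc2cc(Cl)ccc2s1)C1CC1`), compound 2 (`O=C(Nc1nc2ccc(F)cc2s1)C1CC1`) and compound 3 (`CC(C)(C)C(=O)Nc1nc2ccc(Cl)cc2s1`). Compound 1 gives > 50000 nM as a limit of the assay and not a number. Compound 2 gives > 50000 nM and this too is a limit. Compound 3 gives > 50000 nM and this is again a limit. Among the measured compounds shown here, compound 3 therefore has no number of its own, and the whole series so far is summed up by the limit of > 50000 nM in this assay, at which 3 of the 3 values shown sit, in every case.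

Compound 4 (`O=C(Nc1nc2ccc(Cl)cc2s1)C1CCOC1`) carries oxolan-3-yl in place of tert-butyl on a carbonyl carbon. For the measured compounds named here, no step between measured compounds is available to size this change. The expectation rests only on compound 3 and its limit of > 50000 nM as the starting point. The expected step is a number no higher from compound 3 to compound 4 (the limit leaves the size open) and it should stay within the usual scatter in this assay, in neither direction. Another result reported only as a limit is the most likely outcome. The estimate for compound 4 is 50000 nM (expected range 25000 nM to 100000 nM).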

Compound 4, half-maximal inhibitory concentration: > 50000 nM
Compound 4 ended at the assay's limit (the forecaster's own chance of this, stated with the estimate: 85%); the middle value lies on the limit itself.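

In this assay, compound 3 and compound 4 both stay at the assay's limit, so no step can be read between them: the limit of > 50000 nM in this assay, at which 4 of the 4 values shown sit.

The compounds shown leave open whether any change to the carbonyl substituent or the shared core gives a measurable value in this assay.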